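Swapping a pyridine for a fluorophenoxy group: expected solubility

The source may report more compounds than this note shows. Statements on the series, on what has been measured and on what is new or still open speak of the compounds shown alone.

Compound 1 `COc1ccc2[nH]c(C(=O)N3CC(=O)N(Cc4ccccc4)[C@@H](COCc4ccccc4)C3)cc2c1`: 8800 nM
Compound 2 `COc1ccc2[nH]c(C(=O)N3CC(=O)N(Cc4ccccc4)[C@@H](CCN4CCC5(CC4)CC5)C3)cc2c1`: > 25000 nM
Compound 3 `COc1ccc2[nH]c(C(=O)N3CC(=O)N(Cc4ccccc4)[C@@H](Cc4ccccn4)C3)cc2c1`: > 100000 nM

The three measured compounds share one core and differ only in the group on a saturated chain carbon bound to a saturated ring carbon. In a physicochemical assay for solubility, read by spectrophotometry, in phosphate buffer, with a stated time of 2 h, at pH 7.4 (a higher number here means a more soluble compound, a lower number a less soluble compound), compound 1 gives 8800 nM. For compound 2 the assay reports only a limit, > 25000 nM. For compound 3 the result is also a limit, > 100000 nM, so compound 3 stands at the top of what this assay can report and its exact number is not known. Among the measured compounds shown here, the step of an at least 11-fold higher number from compound 1 to compound 3 (1.05 log units; beyond the scatter) is the one firm comparison that reaches compound 3.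

The unmeasured compound 4 `COc1ccc2[nH]c(C(=O)N3CC(=O)N(Cc4ccccc4)[C@@H](COc4ccc(F)cc4)C3)cc2c1` differs from compound 3 by 4-fluorophenoxy in place of pyridin-2-yl on a saturated chain carbon bound to a saturated ring carbon. For the measured compounds named here, no measured step covers this exact exchange. The nearest is an at least 11-fold higher number from compound 1 to compound 3 (1.05 log units; beyond the scatter), in which a benzyloxy group gave way to the pyridin-2-yl group; compound 4 instead carries a 4-fluorophenoxy group, which in shape and make-up is closer to the benzyloxy group of compound 1 than to the pyridin-2-yl group of compound 3. The move from compound 3 to compound 4 is therefore expected to run the other way, as a drop estimated at an at least 10-fold lower number from compound 3 to compound 4 (1.00 log units; beyond the scatter). Compound 4 is expected to give about 10000 nM, with a likely range from 3000 nM to 40000 nM.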

Compound 4, solubility: 17500 nM
For compound 4 the middle estimate is 1.8-fold (0.24 log units) below the measured one; the range from low to high includes it.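

In this assay, putting 4-fluorophenoxy in place of pyridin-2-yl on a saturated chain carbon bound to a saturated ring carbon brings an at least 5.7-fold lower number from compound 3 to compound 4 (0.75 log units; beyond the scatter), so a second group with an oxygen in its link, after benzyloxy, also falls well short of the pyridine compound. That step is a floor and not a full size: the limit of > 100000 nM in this assay, at which 1 of the 4 values shown sits.

The two oxygen-linked groups are not told apart, since 4-fluorophenyl in place of benzyl on an oxygen on a saturated carbon gives a 2.0-fold higher number from compound 1 to compound 4 (0.30 log units; within the scatter), and the comparison with the larger ring group gives only an at least 1.4-fold lower number from compound 2 to compound 4 (0.15 log units; that floor lies within the scatter), so no firm order follows from it.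

The step between compound 2 and compound 3 cannot be read, and compound 3 differs from compound 4 both in its ring nitrogen and in lacking the oxygen link, so the shown compounds cannot say which of the two goes with its limit. A plain phenyl group on the same chain carbon, or a pyridin-2-yloxy group, would pull those two features apart.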